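The compounds below may be only part of what the source reports. "The series", "measured", "known", "first", "only" and "open" are said of these compounds alone.

Measured so far in a physicochemical assay for solubility, read by HPLC, using the shake flask method, with a stated time of 2 h, at pH 2 (on this read-out higher numbers stand for higher solubility and lower numbers for lower solubility), for this series
- compound 1 `NC(=O)c1ccc(-c2cnc(N)c(-c3ccc(C(F)(F)F)cc3)n2)cc1` gives 80000 nM
- compound 2 `Nc1ncc(-c2ccc(C(=O)N3CCC(O)C3)cc2)nc1-c1ccc(C(F)(F)F)cc1` gives 129000 nM

Among the measured compounds shown here, compound 2 stands level with compound 1, the one measured step being a 1.6-fold higher number from compound 1 to compound 2 (0.21 log units; within the scatter) and no more. Compound 3 `Nc1ncc(-c2ccc(C(=O)N3CC[C@@H](O)C3)cc2)nc1-c1ccc(C(F)(F)F)cc1` is compound 2 with one change: the two compounds have the same atoms and bonds; at least one stereo element is drawn with a configuration in one of them and without one in the other: 1 of 1 stereo elements differ; a stereocentre at a saturated ring carbon is drawn without a configuration in compound 2 and R in compound 3 and nothing else. The measured step swaps a group and leaves this stereocentre aside, so it bears only indirectly. Compound 2 at 129000 nM is therefore the anchor, and no step beyond the scatter is expected in this assay here. The estimated step is a 1.0-fold lower number from compound 2 to compound 3 (0.01 log units; within the scatter) and it stays within the scatter. Compound 3 is expected near 125000 nM with an estimated range of 65000 nM to 230000 nM in all.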

Compound 3, solubility: 103000 nM
Beside the measured number, compound 3's estimate is 1.2-fold (0.08 log units) above it; the range from low to high includes it.
By their numbers in this assay, from the lowest: compounds 1, 3 and 2 (each within the scatter of the next).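

In this assay, the stereocentre at the saturated ring carbon gives a 1.3-fold lower number from compound 2 to compound 3 (0.10 log units; within the scatter), so drawing it as R leaves the number level. With the R configuration, the 3-hydroxypyrrolidin-1-yl in place of amino on the carbonyl carbon also stays level, at a 1.3-fold higher number from compound 1 to compound 3 (0.11 log units; within the scatter). No comparison between the two configurations follows, because of one fact: the fact that one of compounds 2 and 3 is drawn with a defined configuration and the other without, at the place where they differ.

Going by these compounds, the S configuration at this stereocentre remains open. So does whether a basic amine such as piperazine or a carboxylic acid on the carbonyl carbon would leave the number equally level.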